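The source may hold more compounds than are shown below. What is called first, only, known or untested is meant among the compounds shown, and "the series" means these compounds.

Of the compounds shown here, three have been measured in a functional assay on Bel-7402 cells (Homo sapiens) for inhibition, read by MTT assay, with a stated time of 24 h, tested at 0.1 ug/mL; on this read-out higher numbers stand for more inhibition of growth at the one concentration tested and lower numbers for less inhibition of growth. Compound 1 `O=C(CCCCC1CCSS1)Nc1ccccc1Cl` gives 6.83%, compound 2 `O=C(CCCCC1CCSS1)Nc1cccc2ccccc12` gives 3.4%, and compound 3 `O=C(CCCCC(S)CCS)Nc1ccccc1Cl` gives 5.11%; all three numbers lie within the scatter of one another. The difference between the cores of compound 1 and compound 2 is not broken down here. Opening the ring, (a group of 5 heavy atoms (3 carbon, 2 sulfur; no ring) in place of a group of 5 heavy atoms (3 carbon, 2 sulfur; one five-membered non-aromatic ring with 2 hetero atoms), on a saturated chain carbon, four bonds along the chain from a carbonyl carbon), gave a number 1.7 percentage points lower from compound 1 to compound 3 (within the scatter). The unmeasured compound 4 `O=C(CCCCC(S)CCS)Nc1cccc2ccccc12` carries the same change on the core of compound 2: a group of 5 heavy atoms (3 carbon, 2 sulfur; no ring) in place of a group of 5 heavy atoms (3 carbon, 2 sulfur; one five-membered non-aromatic ring with 2 hetero atoms), on a saturated chain carbon, four bonds along the chain from a carbonyl carbon. Because the step of a number 1.7 percentage points lower from compound 1 to compound 3 (within the scatter) stayed within the scatter, the step is expected to be small again, a number 0.4 percentage points lower from compound 2 to compound 4 (within the scatter). Compound 4 is therefore estimated to give 3% in this assay, with a range from -6% to 12%.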

Compound 4, percent growth inhibition at one concentration: "not active" (no number reported)
Nothing numeric was reported for compound 4, and the estimate cannot be compared.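

Among the compounds shown here, compound 4 is reported without a number, so no step from compound 2 to compound 4 can be read in this assay. The compounds shown leave open how far opening the ring shifts growth inhibition on the core of compound 2. No measured evidence bears on this result.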